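A few compounds are considered here, and "the series" means these few. Any claim that something is new, unique, unknown or untested is made for them only; others in the source may bear on it.

In a physicochemical assay for lipophilicity, at pH 7.4 (a lower number here means a more polar compound, a higher number a more lipophilic compound), compound 1 (`COc1cc2[nH]c(C)c(C3CCCCC3)c(=O)c2cc1Cl`) gives 3.04 and compound 2 (`COc1cc2[nH]c(C)c(C(C)C)c(=O)c2cc1Cl`) gives 2.84, the step between them being a number 0.20 log units lower from compound 1 to compound 2 (within the scatter) on the shared core. Among the measured compounds shown here, compound 3 (`C=C(CCCCC)c1c(C)[nH]c2cc(OC)c(Cl)cc2c1=O`) stands highest of the three in this assay at 3.58 and no other compound lies within the scatter of it. Compound 4 (`CCCCC/C=C/c1c(C)[nH]c2cc(OC)c(Cl)cc2c1=O`) has the same atoms joined differently, and the change is a group of 7 heavy atoms (7 carbon; no ring) in place of a group of 7 heavy atoms (7 carbon; no ring), on an aromatic carbon with hept-1-en-1-yl as the entering group. Two measured steps end at the same group of compound 3, namely a number 0.54 log units higher from compound 1 to compound 3 (beyond the scatter) and a number 0.74 log units higher from compound 2 to compound 3 (beyond the scatter) but both of them also alter the heavy-atom count or remove a ring, and neither alteration occurs here. They therefore set no size for this change, and no step beyond the scatter is expected in this assay for either direction. The expected step is small (a number 0.02 log units higher from compound 3 to compound 4 (within the scatter)). For compound 4 the estimated value is 3.6 (range 3.2 to 4).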

Compound 4, distribution coefficient: 3.57
Beside the measured number, compound 4's estimate is 0.03 log units above it; low and high end bracket the measured number.
By their numbers in this assay, from the lowest: compounds 2 and 1 (each within the scatter of the next); then compounds 4 and 3 (each within the scatter of the next).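

Rearranging the atoms of the group on this aromatic carbon to give hept-1-en-1-yl leaves the reading in this assay unchanged within the scatter (a number 0.01 log units lower from compound 3 to compound 4 (within the scatter)), so this assay does not separate the two open-chain groups. The gain over the earlier groups also holds for hept-1-en-1-yl, beyond the scatter against both isopropyl (a number 0.73 log units higher from compound 2 to compound 4 (beyond the scatter)) and cyclohexyl (a number 0.53 log units higher from compound 1 to compound 4 (beyond the scatter)), so it is not confined to the group of compound 3. No measurement is available that bears on the reason for these steps.

The compounds shown leave open whether a saturated heptyl chain or a longer chain at this position would read the same. They also leave open what an amine or a carboxylic acid at the end of such a chain would do to the number.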